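Oxazolyl ketone series: chain in place of pyridinyl

The source may hold more compounds than are shown below. What is called first, only, known or untested is meant among the compounds shown, and "the series" means these compounds.

Measured compounds:
compound 1 `O=C(CCCCCCc1ccccc1)c1ncc(-c2ccc(CCl)cn2)o1` — 24 nM
compound 2 `CSC(=O)CCCCc1cnc(C(=O)CCCCCCc2ccccc2)o1` — 1.7 nM
compound 3 `N#CCCCCCc1cnc(C(=O)CCCCCCc2ccccc2)o1` — 4.4 nM

In an assay for inhibition of Fatty-acid amide hydrolase 1 (Rattus norvegicus), using a Dixon plot, with a stated time of 1 h (a higher number here means a weaker inhibitor, a lower number a stronger inhibitor), compound 1 gives the highest of the three numbers; compound 3 lies nearest (a 5.5-fold lower number from compound 1 to compound 3 (0.74 log units; beyond the scatter)) and compound 2 furthest (a 14-fold lower number from compound 1 to compound 2 (1.15 log units; beyond the scatter)). Between the two chain analogues, a 2.6-fold higher number from compound 2 to compound 3 (0.41 log units; beyond the scatter).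

Compound 4 `O=C(CCCCCCc1ccccc1)c1ncc(CCCCCBr)o1` is the unmeasured member. Relative to compound 1 the change is a group of 6 heavy atoms (5 carbon, 1 bromine; no ring) in place of a group of 8 heavy atoms (6 carbon, 1 nitrogen, 1 chlorine; one six-membered aromatic ring with 1 hetero atom), on an aromatic carbon. Both measured steps from compound 1 bear on this: each swaps the same pyridinyl group for an open chain on the same ring carbon, and each lowered the number beyond the scatter, by a modest amount in a 5.5-fold lower number from compound 1 to compound 3 (0.74 log units; beyond the scatter) and by a large amount in a 14-fold lower number from compound 1 to compound 2 (1.15 log units; beyond the scatter). The 5-bromopentyl group carries neither the thioester nor the nitrile, so the step for compound 4 is expected to fall in the modest range, toward a lower number. Compound 4 is therefore estimated at 5 nM, range 1.5 nM to 15 nM, an expected step of a 4.8-fold lower number from compound 1 to compound 4 (0.68 log units; beyond the scatter).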

Compound 4, inhibition constant: 6.1 nM
The estimate for compound 4 lay 1.2-fold (0.09 log units) below the measured number; measured number inside the range.
By their numbers in this assay, from the lowest: compound 2; then compounds 3 and 4 (each within the scatter of the next); then compound 1.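

In this assay, a third open chain on the aromatic carbon next to the ring oxygen again improves on the pyridinyl group, a 3.9-fold lower number from compound 1 to compound 4 (0.59 log units; beyond the scatter), and the 5-bromopentyl group does so with no hydrogen-bond acceptor, so the lower number does not depend on an acceptor in the chain. The chain end separates only part of the series: bromo in place of cyano gives a 1.4-fold higher number from compound 3 to compound 4 (0.14 log units; within the scatter), whereas bromomethyl in place of (methylsulfanyl)carbonyl gives a 3.6-fold higher number from compound 2 to compound 4 (0.55 log units; beyond the scatter), leaving the thioester compound 2 apart from the other two chains. Nothing shown accounts for these differences.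

Still open, from the compounds shown here alone, is how a carboxylic acid or an amine at the chain end would compare with the thioester. Also open, going by these compounds, is whether a longer chain ending in bromo would differ from the 5-bromopentyl group.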